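Giving up the 4-propylpiperazin-1-yl group

The source may hold more compounds than are shown below. What is called first, only, known or untested is meant among the compounds shown, and "the series" means these compounds.

In a functional assay on MCF7 cells (Homo sapiens) for cytotoxicity, read by MTT assay, with a stated time of 72 h (a higher number here means a weaker inhibitor, a lower number a stronger inhibitor), compound 1 (`O=C1c2c[n+]([O-])c3ccccc3c2C(=O)c2c1c1ccccc1n2CCCCN1CCCCC1`) gives 150 nM and compound 2 (`CCCN1CCN(CCCCn2c3c(c4ccccc42)C(=O)c2c[n+]([O-])c4ccccc4c2C3=O)CC1`) gives 1280 nM, so compound 2 holds the higher of the two numbers and is the weaker inhibitor of the pair. Compound 3 (`CN(C)CCCCn1c2c(c3ccccc31)C(=O)c1c[n+]([O-])c3ccccc3c1C2=O`) differs from compound 2 in one place: dimethylamino in place of 4-propylpiperazin-1-yl on a saturated chain carbon, four bonds along the chain from an aromatic nitrogen. Dimethylamino stands in place of 4-propylpiperazin-1-yl on a saturated chain carbon, four bonds along the chain from an aromatic nitrogen. Among the measured compounds shown here, one measured step bears on this change, at the same place: an 8.5-fold higher number from compound 1 to compound 2 (0.93 log units; beyond the scatter), with 4-propylpiperazin-1-yl in place of piperidin-1-yl. For the measured compounds named here, no dimethylamino compound has a measured value yet, so this single step is thin evidence. Compound 3 also loses the 4-propylpiperazin-1-yl group, so a return toward compound 1 is expected, perhaps only a partial one. The expected step is a 3.7-fold lower number from compound 2 to compound 3 (0.56 log units; beyond the scatter), somewhat smaller than the measured one and towards a lower number. For compound 3 the estimated value is 350 nM, with an expected range of 110 nM to 1000 nM.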

Compound 3, half-maximal inhibitory concentration: 220 nM
Beside the measured number, compound 3's estimate is 1.6-fold (0.20 log units) above it; the range from low to high includes it.
By their numbers in this assay, from the lowest: compounds 1 and 3 (each within the scatter of the next); then compound 2.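

In this assay, dimethylamino in place of 4-propylpiperazin-1-yl on the saturated chain carbon gives a 5.8-fold lower number from compound 2 to compound 3 (0.76 log units; beyond the scatter), so a group with no ring takes the number back down from that of compound 2. Set against piperidin-1-yl at the same place, the change gives a 1.5-fold higher number from compound 1 to compound 3 (0.17 log units; within the scatter), so at this place the ring of compound 1 is not required for a number of this size, and the 4-propylpiperazin-1-yl group of compound 2 alone stands apart among the three. Nothing measured here explains why that group differs from the other two.

The compounds shown leave open whether the piperazine ring itself or its propyl group accounts for the higher number of compound 2, a question that a 4-methylpiperazin-1-yl or morpholin-4-yl group at the same place would address. They also leave open whether dimethylamino keeps its number on a shorter or longer chain.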